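A few compounds are considered here, and "the series" means these few. Any claim that something is new, unique, unknown or untested is made for them only; others in the source may bear on it.

Measured compounds: compound 1 `COc1ccc(-c2nc(/N=C(\N)N3CCOCC3)sc2-c2ccc(OC)cc2)cc1`, compound 2 `CNC(=O)NCc1nc(-c2ccc(OC)cc2)c(-c2ccc(OC)cc2)s1`, compound 3 `COc1ccc(-c2nc(CNC(=O)NC(C)C)sc2-c2ccc(OC)cc2)cc1`.

In a functional assay with Oryctolagus cuniculus as the target (a higher number here means a weaker inhibitor, a lower number a stronger inhibitor), compound 1 gives only a limit, < 1000 nM. Compound 2 gives 22 nM. Compound 3 gives 42 nM, the higher of the two numbers, but the step of a 1.9-fold higher number from compound 2 to compound 3 (0.28 log units; within the scatter) lies within the scatter, so the two are not ordered. The steps from compound 1 stay unreadable the limit of < 1000 nM in this assay, at which 1 of the 3 values shown sits: a step that the limit leaves unreadable from compound 1 to compound 2 and a step that the limit leaves unreadable from compound 1 to compound 3.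

Compound 4 `COc1ccc(-c2nc(/C=C/C(=O)O)sc2-c2ccc(OC)cc2)cc1` differs from compound 3 by 2-carboxyethenyl in place of ((isopropylcarbamoyl)amino)methyl on an aromatic carbon. Going by the values given here, the only readable step, a 1.9-fold higher number from compound 2 to compound 3 (0.28 log units; within the scatter), exchanged alkyls on the urea; here the whole ((isopropylcarbamoyl)amino)methyl is replaced by 2-carboxyethenyl, a change no measured step covers. Compound 4 is therefore expected to be weaker, a 4.8-fold higher number from compound 3 to compound 4 (0.68 log units; beyond the scatter), with wide uncertainty. The estimate for compound 4 is 200 nM, range 40 nM to 1500 nM.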

Compound 4, half-maximal inhibitory concentration: > 100 nM
Compound 4: only a limit was reported; the forecaster's own chance of this, stated with the estimate: 15%; the middle value does not contradict the limit.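

In this assay compound 4 gives only a limit, > 100 nM. Even so, the group on this aromatic carbon, next to the ring nitrogen and next to the ring sulfur, matters: 2-carboxyethenyl in place of ((isopropylcarbamoyl)amino)methyl gives an at least 2.3-fold higher number from compound 3 to compound 4 (0.37 log units; beyond the scatter), and in place of ((methylcarbamoyl)amino)methyl it gives an at least 4.5-fold higher number from compound 2 to compound 4 (0.65 log units; beyond the scatter), the first readable steps here beyond the scatter. The step from compound 1 to compound 4 cannot be read: the limit of > 100 nM in this assay, at which 1 of the 4 values shown sits.

Open, as far as these compounds go, is whether the double bond or the carboxylic acid carries these steps. A saturated propanoic acid chain or a simple aminomethyl group at this position would help separate the contributions.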